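Compound 4 Measured Against Three Known Sulfonamides

The compounds below may be only part of what the source reports. "The series", "measured", "known", "first", "only" and "open" are said of these compounds alone.

Three compounds share one core and differ only in the group on the sulfonyl sulfur. Compound 1 `CCN(CC)C(=O)CN(c1ccc(C)cc1)S(=O)(=O)c1ccc(OC(F)(F)F)cc1` gives 1820 nM in a functional assay on CHO cells for inhibition of Orexin receptor type 2 (Homo sapiens), read by FLIPR and calcium flux; a higher number here means a weaker inhibitor, a lower number a stronger inhibitor. Compound 2 `CCN(CC)C(=O)CN(c1ccc(C)cc1)S(=O)(=O)c1cccc(C)c1` gives 60 nM in this assay, and compound 3 `CCN(CC)C(=O)CN(c1ccc(C)cc1)S(=O)(=O)c1cccc(F)c1` gives 839 nM in this assay. Among these three numbers compound 3 stands second highest: its nearest neighbour is compound 1, somewhat above it, while compound 2 lies far below. Going by the values given here, the one measured step, a 14-fold higher number from compound 2 to compound 3 (1.15 log units; beyond the scatter), shows that a single exchange on this ring can move the number strongly. Compound 4 `CCN(CC)C(=O)CN(c1ccc(C)cc1)S(=O)(=O)c1ccc(C#N)cc1` differs from compound 3 by 4-cyanophenyl in place of 3-fluorophenyl on a sulfonyl sulfur. Among the compounds with values here, no measured step covers this exchange, so guidance is indirect: compound 1 shows that another group on this ring can sit in the weak region, and compound 3 itself is already weak. One therefore expects a step of a 1.5-fold higher number from compound 3 to compound 4 (0.19 log units; within the scatter) in this assay of small size, towards a higher number, with wide uncertainty. Compound 4 is estimated at 1300 nM, within a range from 300 nM to 6000 nM.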

Compound 4, half-maximal inhibitory concentration: 1190 nM
Compound 4: the middle estimate sits 1.1-fold (0.04 log units) above what was measured; measured number inside the range.
By their numbers in this assay, from the lowest: compound 2; then compounds 3, 4 and 1 (each within the scatter of the next, the first and the last beyond it).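

In this assay, 4-cyanophenyl in place of 3-fluorophenyl on a sulfonyl sulfur gives a 1.4-fold higher number from compound 3 to compound 4 (0.15 log units; within the scatter) and cyano in place of trifluoromethoxy gives a 1.5-fold lower number from compound 1 to compound 4 (0.18 log units; within the scatter), so compound 4 cannot be told apart from either compound 3 or compound 1. The large step on this ring now appears a second time: 4-cyanophenyl in place of 3-methylphenyl gives a 20-fold higher number from compound 2 to compound 4 (1.30 log units; beyond the scatter), and compound 2 remains the only one of the four with a low number. No evidence on the reason for this result is available here.

The compounds shown leave open whether the low number of compound 2 depends on the methyl group itself or on where it sits on the ring. They also do not tell how an ethyl group, an amine or a carboxylic acid on this ring would read.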